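The compounds below may be only part of what the source reports. "The series", "measured", "known", "first", "only" and "open" are said of these compounds alone.

Compound 1 `NC(=O)c1c(NC(=O)c2ccccc2Cl)sc2c1CCNC2`, compound 2 `Cc1ccc(C(=O)Nc2sc3c(c2C(N)=O)CCN(Cc2ccc(Cl)cc2Cl)C3)cc1` and compound 3 `Cc1ccccc1C(=O)Nc1sc2c(c1C(N)=O)CCN(C(=S)Nc1ccccc1Cl)C2` share one core and were all examined in a functional assay on HeLa cells (Homo sapiens) for antiproliferative activity, with a stated time of 24 h; on this read-out lower numbers stand for stronger inhibition and higher numbers for weaker inhibition. In this assay compound 1 gives 45000 nM. For compound 2 the result is only a limit of the assay, > 50000 nM, and that value matches (the limit of > 50000 nM in this assay, at which 1 of the 3 values shown sits). Compound 3 gives 35300 nM in this assay, which is the lowest of the two numbers reported; the nearest is compound 1, and the gap between the two lies within the scatter, so no order between compound 3 and compound 1 can be drawn from these figures.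

Compound 4 `NC(=O)c1c(NC(=O)c2ccncn2)sc2c1CCN(C(=S)Nc1ccccc1Cl)C2` has not yet been measured in this assay. It differs from compound 3 in one place: pyrimidin-4-yl in place of 2-methylphenyl on a carbonyl carbon. Within the data shown here, no step between two measured compounds is available to weigh this change, and the three results known so far all sit at weak inhibition or at the limit. The step from compound 3 to compound 4 is therefore expected to be small, with no clear direction beyond the scatter: a 1.0-fold lower number from compound 3 to compound 4 (0.00 log units; within the scatter). For compound 4 the estimated value in this assay is 35000 nM, with a range from 8000 nM to 100000 nM.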

Compound 4, half-maximal inhibitory concentration: > 50000 nM
Compound 4: no number, only a limit; the forecaster's own chance of this, stated with the estimate: 35%; middle value at least 1.4-fold (0.15 log units) away from the limit.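

Pyrimidin-4-yl in place of 2-methylphenyl on a carbonyl carbon gives the first step at this position that can be read in this assay: an at least 1.4-fold higher number from compound 3 to compound 4 (0.15 log units; that floor lies within the scatter). Only a floor is known for this step, and as that floor lies within the scatter, the result fixes neither the size of the change nor a firm order between the two compounds. It does show that this exchange, which brings in a ring with 2 hetero atoms and 2 hydrogen-bond acceptors where the 2-methylphenyl group has none, gave no lower number and adds a second compound at the limit: the limit of > 50000 nM in this assay, at which 2 of the 4 values shown sit.

The compounds shown leave open how far the true value of compound 4 lies from that of compound 3, and whether any group on this carbonyl carbon can bring the number clearly down from the weak range seen so far. From the compounds shown here alone, whether a basic amine such as a piperidine, a carboxylic acid or a longer alkyl chain at this place would shift the result in this assay also remains open.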